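This account rests on a few compounds, and the source may have more. Where it says the series, first, only, none or still open, it means among the compounds named here.

Compound 1 `CCCCNC(=O)[C@@H](NC(=O)c1cccc(Cn2ccnc2)c1)[C@@H](C)CC` gives 3% in an assay on HEK293 cells for displacement of a labelled ligand from Type-2 angiotensin II receptor (Homo sapiens), tested at 10 uM; a lower number here means a weaker effect, a higher number a stronger effect of the compound at the concentration tested. Compound 2 `CC[C@H](C)[C@H](NC(=O)c1cccc(Cn2ccnc2)c1)c1nn[nH]n1` is described in this assay as "not active" (no number reported), with no number attached, so it stands at the inactive end alongside compound 1, and no order between them can be read from these two results. For compound 3 `CCCCS(=O)(=O)NNC(=O)[C@@H](NC(=O)c1cccc(Cn2ccnc2)c1)[C@@H](C)CC` the result in this assay is "not determined" (no result reported), which contributes nothing to the comparison.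

The step considered here leads from compound 2 to compound 4 `CC[C@H](C)[C@H](NC(=O)c1cccc(Cn2ccnc2)c1)C(N)=O`, which differs from compound 2 in one place: carbamoyl in place of 2H-tetrazol-5-yl on a saturated chain carbon bound to an amide-type nitrogen and a saturated chain carbon.

Because compound 2 is reported as "not active" (no number reported) and compound 1 gives 3%, there is no measured starting number from which a directional step could be sized; the expectation is therefore for no movement beyond the scatter in this assay, with compound 4 remaining at a low read-out. Compound 4 is expected to show about 5% in this assay, estimated to lie between 0% and 15%.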

Compound 4, a percentage reported as inhibition, at one concentration (the size of the read-out at that concentration, not a potency): "not active" (no number reported)
The entry for compound 4 holds no number, and the estimate cannot be compared.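

Among these compounds, compound 2 and compound 4 both stand without a number in this assay, so no step between them can be read. The compounds shown leave open whether carbamoyl in place of 2H-tetrazol-5-yl alters this read-out at all. No evidence bears on this result.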